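A few compounds are considered here, and "the series" means these few. Any claim that something is new, unique, unknown or untested is made for them only; others in the source may bear on it.

Measured compounds:
Compound 1 `Cn1c(=O)[nH]c2c(cnn2-c2cc(Cl)cc(Cl)c2)c1=N` gives 29%
Compound 2 `Cn1c(=O)[nH]c2c(cnn2-c2ccc(N)cc2)c1=N` gives 0%

Both numbers come from an assay on membranes from brain for binding affinity to adenosine receptor A1 (Rattus norvegicus), read by radioligand binding, tested at 20 uM; on this read-out higher numbers stand for more inhibition at the one concentration tested (going by the name of the read-out) and lower numbers for less inhibition. Among the two, compound 2 stands lowest; its nearest neighbour, compound 1, lies higher by a gap that is beyond the usual scatter of this assay.

Compound 3 `Cn1c(=O)[nH]c2c(cnn2-c2ccc([N+](=O)[O-])cc2)c1=N` is the next compound. It differs from compound 2 in one place: nitro in place of amino on an aromatic carbon. The nitro group enters on an aromatic carbon of the six-membered aromatic ring of carbon only, para to a large group, where the amino group had been.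

Going by the values given here, no measured pair shows this exchange, so nothing here tells how big its effect is. The step is expected to be small, a number 10 percentage points higher from compound 2 to compound 3 (within the scatter), in the upward direction if any, and possibly not beyond the scatter. Compound 3 is therefore estimated at 10%, with a likely range from 0% to 35%.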

Compound 3, a percentage reported as inhibition, at one concentration (the size of the read-out at that concentration, not a potency): 5%
Compound 3: the middle estimate sits 5 percentage points above what was measured; the measured number falls inside the stated range.
By their numbers in this assay, from the lowest: compounds 2 and 3 (each within the scatter of the next); then compound 1.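

In this assay, placing nitro where amino had been, on an aromatic carbon para to a large group, gives a number 5 percentage points higher from compound 2 to compound 3 (within the scatter). The two compounds therefore cannot be told apart at the one concentration tested, even though amino carries a hydrogen-bond donor and nitro carries none, so this exchange at this position has no effect that can be distinguished from the scatter. No measurement available here offers an explanation for this result.

As far as these compounds go, it remains open whether a different group on this same carbon, such as a chlorine atom, a methoxy group, a carboxylic acid or a longer chain, would change the reading beyond the scatter. A single percentage at one concentration is also not a potency, so any weak binding by these two compounds remains unquantified.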